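The source may hold more compounds than are shown below. What is called first, only, known or untested is meant among the compounds shown, and "the series" means these compounds.

Three analogues built on one shared core have been tested in a toxicity assay on WI-38 cells (Homo sapiens) for cytotoxicity, read by MTT assay, with a stated time of 48 h; on this read-out lower numbers stand for stronger inhibition and higher numbers for weaker inhibition. Going by the values given here, compound 1 `O=C(/C=C/c1ccc2c(c1)B(O)OC2)c1ccc(-c2ccccc2)cc1` gives 18300 nM, compound 3 `O=C(/C=C/c1ccc2c(c1)B(O)OC2)c1ccc(C(F)(F)F)cc1` gives 22600 nM, and the step of a 1.2-fold higher number from compound 1 to compound 3 (0.09 log units; within the scatter) is the only single-point change among them. Compound 2 `O=C(/C=C/c1ccc2c(c1)B(O)OC2)c1ccco1` gives 59000 nM, the highest of the three numbers and beyond the scatter from both others. Compound 4 `O=C(/C=C/c1ccc2c(c1)B(O)OC2)c1ccccc1F` differs from compound 2 by 2-fluorophenyl in place of furan-2-yl on a carbonyl carbon. Among the compounds with values here, no measured step covers this exchange; the step of a 1.2-fold higher number from compound 1 to compound 3 (0.09 log units; within the scatter) shows only that two six-membered rings of carbon with different substituents land within the scatter of each other, while compound 2 with furan-2-yl stands higher than both. Compound 4 is therefore expected to give a lower number, a step of a 2.4-fold lower number from compound 2 to compound 4 (0.37 log units; beyond the scatter) in this assay. The estimate for compound 4 is 25000 nM, with a range from 10000 nM to 60000 nM.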

Compound 4, half-maximal inhibitory concentration: 23600 nM
Compound 4: middle estimate off by 1.1-fold (0.03 log units), on the high side; low and high end bracket the measured number.
By their numbers in this assay, from the lowest: compounds 1, 3 and 4 (each within the scatter of the next); then compound 2.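

Going by these compounds alone, putting 2-fluorophenyl in place of furan-2-yl on the carbonyl carbon gives a 2.5-fold lower number from compound 2 to compound 4 (0.40 log units; beyond the scatter) in this assay, the first measured step at this position. Compound 4 joins compounds 1 and 3, each within the scatter of the next, which leaves compound 2 with furan-2-yl apart from the other three. Nothing measured on these groups accounts for this step.

The compounds shown leave open whether unsubstituted phenyl would stay with compound 4. They also leave open whether thiophen-2-yl would stand with compound 2.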